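The compounds below may be only part of what the source reports. "The series", "measured", "known", "first", "only" and "open" are said of these compounds alone.

Measured in a functional assay on MCF7 cells (Homo sapiens) for antiproliferative activity, read by MTT assay, with a stated time of 72 h (on this read-out higher numbers stand for weaker inhibition and lower numbers for stronger inhibition), so far
- compound 1 `CCN1CCN(c2cc(C)c3cc(NC(=O)c4ccccc4F)ccc3n2)CC1` gives 32600 nM
- compound 2 `Cc1cc(N(C)C)nc2ccc(NC(=O)c3ccc(Cl)c(Cl)c3)cc12` gives 33300 nM
- compound 3 `CCN1CCN(c2cc(C)c3cc(NC(=O)c4ccccc4Cl)ccc3n2)CC1` gives > 50000 nM (a limit of the assay)

Within the data shown here, compound 2 stands within the scatter of compound 1, the only other firm number here. Compound 4 `Cc1cc(NCCN2CCCCC2)nc2ccc(NC(=O)c3ccc(Cl)c(Cl)c3)cc12` carries (2-(piperidin-1-yl)ethyl)amino in place of dimethylamino on an aromatic carbon, next to the ring nitrogen ((2-(piperidin-1-yl)ethyl)amino in place of dimethylamino on an aromatic carbon). Among the measured compounds shown here, the only measured step of an at least 1.5-fold higher number from compound 1 to compound 3 (0.18 log units; that floor lies within the scatter) sits at another place on the molecule and gives no size for this change. With no measured guide, a modest move to a lower number in this assay is expected, and a result within the scatter would be no surprise. The expected step is a 2.2-fold lower number from compound 2 to compound 4 (0.35 log units; beyond the scatter) and remains uncertain. For compound 4 the estimated value is 15000 nM (3000 nM to 50000 nM) on present evidence.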

Compound 4, half-maximal inhibitory concentration: 1190 nM
Compound 4: middle estimate off by 13-fold (1.10 log units), on the high side; the measured number lies below the stated range.
By their numbers in this assay, from the lowest: compound 4; then compounds 1 and 2 (each within the scatter of the next). At a limit, above all of these: compound 3.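

In this assay, replacing dimethylamino with (2-(piperidin-1-yl)ethyl)amino gives a 28-fold lower number from compound 2 to compound 4 (1.45 log units; beyond the scatter). This shows that the group on this aromatic carbon, next to the ring nitrogen, can move the read-out far beyond the scatter, a size that the earlier step at another place on the molecule did not reveal. Nothing measured here gives a reason for this step. On these data alone, the change swaps the chain, the ring and the amine hydrogen together, so their separate shares remain open. Also open, as far as these compounds go, is how a morpholine ring in place of the piperidine, or a shorter or longer chain, would read at this position.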